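A few compounds are considered here, and "the series" means these few. Any claim that something is new, unique, unknown or untested is made for them only; others in the source may bear on it.

Measured compounds in the series:
- compound 1 `Nc1nc(=O)ccn1[C@@H]1O[C@H](COP(=O)(O)O)[C@@H](O)[C@H]1O`: in an in vitro functional assay on 1321-N1 cells for agonist activity at P2Y purinoceptor 6 (Homo sapiens), read by scintillation proximity assay and inositol phosphate accumulation (on this read-out higher numbers stand for an effect only at larger amounts of compound and lower numbers for an effect already at smaller amounts), compound 1 gives > 100000 nM
- compound 2 `CSc1nc(=O)ccn1[C@@H]1O[C@H](COP(=O)(O)O)[C@@H](O)[C@H]1O`: in this assay compound 2 gives > 100000 nM

The value shown for compound 1 is a limit of the assay and not a number. The value shown for compound 2 is likewise a limit. Both therefore sit at the limit of > 100000 nM in this assay, at which 2 of the 2 values shown sit, and the step that the two limits leave unreadable from compound 1 to compound 2 cannot be read from them. Compound 2 thus stands only at the limit, with no number for it on this read-out.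

Compound 3 `COc1nc(=O)ccn1[C@@H]1O[C@H](COP(=O)(O)O)[C@@H](O)[C@H]1O` differs from compound 2 by methoxy in place of methylsulfanyl on an aromatic carbon. Among the compounds with values here, the one measured step, from compound 1 to compound 2, concerns a change at the same place of the shared core but gives no size, so it offers no readable step to carry over. With both known values at the limit, no step beyond the scatter in either direction can be argued for compound 3.

Compound 3 is therefore expected to return a limit as well, with an estimate of 200000 nM and a range of 60000 nM to 1000000 nM. The expected step is a step that the limit leaves unreadable from compound 2 to compound 3.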

Compound 3, half-maximal effective concentration: 9800 nM
Beside the measured number, compound 3's estimate is 20-fold (1.31 log units) above it, and the stated range ends above it.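

Within the data shown here, compound 3 is the first to give a number in this assay, so this position, on an aromatic carbon between two ring nitrogen atoms, can carry a group that leaves the limit. Methoxy in place of methylsulfanyl gives an at least 10-fold lower number from compound 2 to compound 3 (1.00 log units; beyond the scatter), although the two groups have the same counts of heavy atoms, hydrogen-bond donors and hydrogen-bond acceptors, and differ in having oxygen where the other has sulfur; methoxy in place of amino gives an at least 10-fold lower number from compound 1 to compound 3 (1.00 log units; beyond the scatter). The size of each step is bounded on one side only, and no order can be read for the two compounds at the limit: the limit of > 100000 nM in this assay, at which 2 of the 3 values shown sit.

On these data alone, it remains open how far the values of compound 1 and compound 2 lie from that of compound 3, and so how large either step truly is. Also open, as far as these compounds go, is whether a longer chain on the oxygen, such as ethoxy or propoxy, or a hydroxyl or a dimethylamino group at the same place, would give a number in this assay and on which side of compound 3 it would fall.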